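Remote aryl swap on the shared core of compound 1

This account rests on a few compounds, and the source may have more. Where it says the series, first, only, none or still open, it means among the compounds named here.

Measured compounds:
compound 1 `COc1ccc(F)cc1CNCCCNc1ccnc2cc(Cc3ccc(C#N)cc3)ccc12` — 9.47
compound 2 `COc1cccc(CNCCCNc2ccnc3cc(Cc4ccc(C#N)cc4)ccc23)c1O` — 9.47

In a physicochemical assay for acid dissociation, compound 1 gives 9.47, and compound 2 gives 9.47. The step of no change at the digits printed from compound 1 to compound 2 (within the scatter) exchanges the aryl group on a saturated chain carbon bound to an amine nitrogen, and the read-out does not move beyond the scatter. Compound 1 therefore stands level with compound 2.

Compound 3 `COc1ccc(F)cc1CNCCCNc1ccnc2cc(Oc3ccc(Cl)cc3)ccc12` is not yet measured. It differs from compound 1 at a different place: 4-chlorophenoxy in place of 4-cyanobenzyl on an aromatic carbon. Within the data shown here, no measured step alters this part of the shared core, so the only guide is that the one aryl exchange seen, no change at the digits printed from compound 1 to compound 2 (within the scatter), left this assay unchanged. A step of about a number 0.03 log units higher from compound 1 to compound 3 (within the scatter) is expected from compound 1 to compound 3, none beyond the scatter. For compound 3 the estimate is 9.5, within 9.1 to 9.9.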

Compound 3, acid dissociation constant: 9.28
The estimate for compound 3 lay 0.22 log units above the measured number; measured number inside the range.
By their numbers in this assay, from the lowest: compounds 3, 1 and 2 (each within the scatter of the next).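

In this assay, the exchange of 4-cyanobenzyl for 4-chlorophenoxy on an aromatic carbon of the shared core gives a number 0.19 log units lower from compound 1 to compound 3 (within the scatter). Among these compounds, this extends what the earlier compounds showed, since they varied only the aryl group on the saturated chain carbon: a second place in the molecule, carrying a different linking atom to its aromatic ring, also leaves the read-out within the scatter. Nothing available explains why the read-out stays within the scatter at this position.

The compounds shown leave open whether a group of another kind on this aromatic carbon, such as an amine or a carboxylic acid, would move the read-out beyond the scatter. They also leave open whether a longer chain between the two nitrogens would do so.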